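Phenyl in Place of Isopropyl: Compound 3 to Compound 4

A few compounds are considered here, and "the series" means these few. Any claim that something is new, unique, unknown or untested is made for them only; others in the source may bear on it.

Measured so far:
compound 1, `CCOC(=O)C(=O)Nc1c(C)ccccc1=O`: 4%
compound 2, `CCOC(=O)C(=O)Nc1ccc(OC)ccc1=O`: 31%
compound 3, `CC(C)OC(=O)C(=O)Nc1cccccc1=O`: 63%

In a functional assay on the whole organism (strain Sprague-Dawley CD) for inhibition, with Rattus norvegicus as the target, read by paw edema, at a dose of 30 mg/kg by the oral route (a higher number here means a stronger effect of the compound at the dose given, a lower number a weaker effect), compound 3 gives 63%, the highest of the three numbers. Compound 2 stands nearest, lower by a gap beyond the scatter, and compound 1 furthest, also beyond the scatter. No two of these compounds differ in just one place, so none of them shows what a single change does.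

Compound 4, `O=C(Nc1cccccc1=O)C(=O)Oc1ccccc1`, differs from compound 3 in one place: phenyl in place of isopropyl on an oxygen next to a carbonyl group. Nothing measured tells how this swap acts. A small step in this assay is expected, most likely downward, though it could stay within the scatter. Compound 4 is expected to give about 50%, between 25% and 72%, a step of a number 13 percentage points lower from compound 3 to compound 4 (beyond the scatter).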

Compound 4, a percentage reported as inhibition, in the whole organism at one dose (the size of the read-out at that dose, not a potency): 31%
Estimate against measurement, compound 4: 19 percentage points above, within the range that was stated.
By their numbers in this assay, from the lowest: compound 1; then compounds 2 and 4 (each within the scatter of the next); then compound 3.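

For the compounds shown here, this is the first single change that can be read: in this assay, phenyl in place of isopropyl on an oxygen next to a carbonyl group gives a number 32 percentage points lower from compound 3 to compound 4 (beyond the scatter). The group on this oxygen therefore matters for the effect at the dose given, and here the aromatic ring goes with the lower number. No measurement on hand explains the drop. The compounds shown leave open whether the ring itself or the larger number of heavy atoms goes with it. A cyclohexyl group or a longer chain such as butyl on this oxygen would help separate the two.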